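This account rests on a few compounds, and the source may have more. Where it says the series, first, only, none or still open, it means among the compounds named here.

All values below come from an assay on isolated protein for activation of cGMP-dependent protein kinase 1 (Homo sapiens), read by ADP-Glo, with stated times of 30 min and 2 h; on this read-out lower numbers stand for an effect already at smaller amounts and higher numbers for an effect only at larger amounts of compound.

compound 1 `Cc1cc(C(=O)O)ccc1CN1CC[C@H](OC(CO)c2cc(Cl)cc(Cl)c2)[C@@H]1c1ccccc1`: 185000 nM
compound 2 `OC[C@@H](O[C@H]1CCCN(Cc2ncc[nH]2)[C@H]1c1ccccc1)c1cc(Cl)cc(Cl)c1`: > 200000 nM
compound 3 `Cc1cc(C(=O)O)ccc1CN1CCC[C@H](O[C@H](CF)c2cc(Cl)cc(Cl)c2)[C@@H]1c1ccccc1`: 20000 nM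

Compound 2 stands at a limit of this assay and carries no number; the value > 200000 nM is that limit (the limit of > 200000 nM in this assay, at which 1 of the 3 values shown sits). Compound 1 and compound 3 do carry numbers, and of the two, compound 3 sits at the lower one.

The unmeasured compound 4 `O=C(O)c1ccc(CN2CCC[C@H](O[C@H](CO)c3cc(Cl)cc(Cl)c3)[C@@H]2c2ccccc2)cc1` departs from compound 2 by 4-carboxyphenyl in place of 1H-imidazol-2-yl on a saturated chain carbon bound to an amine nitrogen in a ring, or, cut one bond further out, (1H-imidazol-2-yl)methyl to 4-carboxybenzyl. Among the compounds with values here, no pair of measured compounds differs in exactly one place, so no measured step can be quoted for this change. Compound 1 and compound 3, which both carry a carboxybenzyl group on the ring nitrogen, give numbers in this assay, whereas compound 2 does not. For compound 4 the step of an at least 2.2-fold lower number from compound 2 to compound 4 (0.34 log units; beyond the scatter) is therefore expected to go toward smaller amounts, beyond the scatter, though a limit remains possible. Compound 4 is estimated at 90000 nM, between 25000 nM and 300000 nM.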

Compound 4, half-maximal effective concentration: 77000 nM
Beside the measured number, compound 4's estimate is 1.2-fold (0.07 log units) above it; the measured number falls inside the stated range.
By their numbers in this assay, from the lowest: compound 3; then compound 4; then compound 1. At a limit, above all of these: compound 2.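

Within the data shown here, on a saturated chain carbon bound to an amine nitrogen in a ring, 4-carboxyphenyl in place of 1H-imidazol-2-yl gives an at least 2.5-fold lower number from compound 2 to compound 4 (0.41 log units; beyond the scatter) in this assay, the first step that can be read for a change in one place. This single change is enough to turn a result without a number into a measured one, so the group at this position matters for the read-out. Compound 2 carries a limit and no number: the limit of > 200000 nM in this assay, at which 1 of the 4 values shown sits.

On these data alone, it remains open whether the carboxylic acid or the phenyl ring accounts for the step, which a plain benzyl or a primary amide in place of the acid would separate. As far as these compounds go, it is also open how a longer chain between the ring nitrogen and the phenyl ring would read.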